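The compounds below may be only part of what the source reports. "The series", "measured", "known", "first", "only" and "open" are said of these compounds alone.

Of the compounds shown here, two have been measured so far. Compound 1 `COc1ccc(-n2nnnc2Nc2ccccc2Cl)cc1` gives 246000 nM in an ADME assay on V79 cells (Cricetulus griseus) for cytotoxicity, read by MTT assay, with a stated time of 72 h; a higher number here means a weaker inhibitor, a lower number a stronger inhibitor. Compound 2 `COc1ccc(Nc2nnnn2-c2ccc(F)cc2)cc1`, a close relative, gives 145000 nM in this assay. Compound 1 holds the larger of these two numbers, but its gap to compound 2 lies within the usual scatter of the measurement, so the two cannot be told apart. The unmeasured compound 3 `COc1ccc(-n2nnnc2Nc2cccc(F)c2)cc1` is reached from compound 1 by a single change: 3-fluorophenyl in place of 2-chlorophenyl on a nitrogen on an aromatic ring. Within the data shown here, no step between measured compounds shows what such a swap does, and the only other measured compound, compound 2, sits within the scatter of compound 1. On that basis no shift beyond the scatter is expected in this assay from the step of a 1.2-fold lower number from compound 1 to compound 3 (0.09 log units; within the scatter). For compound 3 the expected value in this assay is estimated at 200000 nM, in a range from 90000 nM to 450000 nM.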

Compound 3, half-maximal inhibitory concentration: 248000 nM
The estimate for compound 3 lay 1.2-fold (0.09 log units) below the measured number; the range from low to high includes it.
By their numbers in this assay, from the lowest: compounds 2, 1 and 3 (each within the scatter of the next).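

Among these compounds, on a nitrogen on an aromatic ring, 3-fluorophenyl in place of 2-chlorophenyl gives a 1.0-fold higher number from compound 1 to compound 3 (0.00 log units; within the scatter) in this assay, the first direct reading of a single swap at this position. Among the compounds shown here, the step changes both the halogen and its numbered place on the phenyl group, and the reading cannot separate these two changes; it shows only that this combined swap leaves the number within the scatter. Nothing available explains this outcome.

The compounds shown cover only two halogen-bearing phenyl groups at this position, so they leave open whether a phenyl group carrying an amine or a carboxylic acid would shift the number beyond the scatter. They also leave open what a longer chain in place of the phenyl group would do.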